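The source may report more compounds than this note shows. Statements on the series, on what has been measured and on what is new or still open speak of the compounds shown alone.

Of the compounds shown here, three have been measured so far in a functional assay on CCRF-CEM cells for agonist activity at C-X-C chemokine receptor type 4 (Homo sapiens), read by calcium flux, with a stated time of 25 min; a higher number here means that more compound is needed for the effect, a lower number that less compound is needed. Compound 1 `c1cnc2c(c1)CCC[C@@H]2N(CC1CC1)C[C@H]1Cc2c(cccc2N2CCNCC2)CN1` returned only a limit, > 30000 nM. Compound 2 `C[C@@H]1CN(c2cccc3c2C[C@H](CN(C)[C@H]2CCCc4cccnc42)NC3)C[C@H](C)N1` likewise gave a limit, > 30000 nM. Compound 3 `Cc1cnc(CN(C)C[C@H]2Cc3c(cccc3N3CCNCC3)CN2)c(C)c1` also sits at a limit, > 30000 nM. Because all three values are limits, none can be ordered against another, and compound 2 stands exactly where every other value stands, at the limit of > 30000 nM in this assay, at which 3 of the 3 values shown sit. For the measured compounds named here, no step between measured compounds can be given.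

Compound 4 `CN(C[C@H]1Cc2c(cccc2N2CCNC(C)(C)C2)CN1)[C@H]1CCCc2cccnc21` shares all its atoms with compound 2, joined differently: the change is 3,3-dimethylpiperazin-1-yl in place of 3,5-dimethylpiperazin-1-yl on an aromatic carbon. Going by the values given here, with every value so far a limit, there is no measured step on which to size this change. The expected step is a step that the limit leaves unreadable from compound 2 to compound 4, meaning no move beyond the scatter, and compound 4 is expected most likely to be reported again only as a limit. The estimate for compound 4 in this assay is 50000 nM, within a range from 15000 nM to 200000 nM.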

Compound 4, half-maximal effective concentration: > 30000 nM
Compound 4 was reported as a limit; the forecaster's own chance of this, stated with the estimate: 85%; the middle value is on the limit's open side.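

Compound 4 gives only a limit in this assay, so no step can be read between compound 2 and compound 4: the limit of > 30000 nM in this assay, at which 4 of the 4 values shown sit.

The compounds shown leave open whether 3,3-dimethylpiperazin-1-yl and 3,5-dimethylpiperazin-1-yl differ at all, and what any of these compounds would read in this assay as an actual number.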